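Swapping ethoxy for chloro on compound 3

This account rests on a few compounds, and the source may have more. Where it says the series, first, only, none or still open, it means among the compounds named here.

Measured so far in a physicochemical assay for lipophilicity, read by mass spectrometry; a lower number here means a more polar compound, a higher number a more lipophilic compound
- compound 1 `COc1cc2c(cc1OC)C(=O)C(C(=O)Nc1ccccc1)C2` gives 2.2
- compound 2 `COc1cc2c(cc1OC)C(=O)C(C(=O)Nc1ccc(Cl)cc1)C2` gives 2.76
- compound 3 `CCOc1cccc(NC(=O)C2Cc3cc(OC)c(OC)cc3C2=O)c1` gives 2.42

Compound 3 lies within the scatter of compound 1, while compound 2 stands higher than both. The next compound, compound 4 `COc1cc2c(cc1OC)C(=O)C(C(=O)Nc1cccc(Cl)c1)C2` is not yet measured. The change from compound 3 is chloro in place of ethoxy on an aromatic carbon (chloro in place of ethoxy on an aromatic carbon, meta to a large group).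

Within the data shown here, two measured steps bear on this: a number 0.56 log units higher from compound 1 to compound 2 (beyond the scatter) with chloro in place of hydrogen, and a number 0.22 log units higher from compound 1 to compound 3 (within the scatter) with ethoxy in place of hydrogen. Among the measured compounds shown here, no measured compound carries chloro at the place it takes in compound 4, so these steps are only a guide. Taking the ethoxy step away from the chloro step, a modest rise in this assay is expected, an estimated a number 0.33 log units higher from compound 3 to compound 4 (beyond the scatter) for this swap.

Compound 4 is expected to read 2.75 (estimated range 2.45 to 3.05).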

Compound 4, partition coefficient: 2.76
Compound 4: the middle estimate sits 0.01 log units below what was measured; measured number inside the range.
By their numbers in this assay, from the lowest: compounds 1 and 3 (each within the scatter of the next); then compounds 2 and 4 (each within the scatter of the next).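

In this assay, having 3-chlorophenyl in place of 4-chlorophenyl on the amide-type nitrogen makes no real difference, with no change at the digits printed from compound 2 to compound 4 (within the scatter), and chloro in place of hydrogen at the new place gives a number 0.56 log units higher from compound 1 to compound 4 (beyond the scatter). At the place meta to a large group, where ethoxy and chloro can now be compared directly, the swap gives a number 0.34 log units higher from compound 3 to compound 4 (beyond the scatter), so at this place the choice between the two groups shows in the reading. Nothing available explains the size of these steps.

On these data alone, whether a fluoro group, a nitrile, an amine or a carboxylic acid at this place would read closer to chloro or to ethoxy remains open. So does the effect of a second chloro on the same ring.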